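Swapping Thiophen-3-yl for Phenyl in Leukemia Cells

A few compounds are considered here, and "the series" means these few. Any claim that something is new, unique, unknown or untested is made for them only; others in the source may bear on it.

Three compounds sharing a sugar-bearing fused core were tested in a functional assay on K562 cells (Homo sapiens), read by MTT assay, with a stated time of 72 h; a higher number here means a weaker inhibitor, a lower number a stronger inhibitor. Compound 1, `Nc1nc2c(c(-c3ccccc3)cn2[C@@H]2O[C@H](CO)[C@@H](O)[C@H]2O)c(=O)[nH]1`, reached only a limit of the assay, > 20000 nM, and gave no number. Compound 2, `COc1ncnc2c1c(-c1ccccc1)cn2[C@@H]1O[C@H](CO)[C@@H](O)[C@H]1O`, likewise stopped at a limit, > 20000 nM. Compound 3, `CNc1ncnc2c1c(-c1ccsc1)cn2[C@@H]1O[C@H](CO)[C@@H](O)[C@H]1O`, also stopped at a limit, > 20000 nM. So compound 3 stands exactly where the other two stand: the evidence is the limit of > 20000 nM in this assay, at which 3 of the 3 values shown sit, and no measured compound shows a number beneath it.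

Compound 4, `CNc1ncnc2c1c(-c1ccccc1)cn2[C@@H]1O[C@H](CO)[C@@H](O)[C@H]1O`, has not yet been measured. It differs from compound 3 in one place: phenyl in place of thiophen-3-yl on an aromatic carbon. No measured pair differs by this same change, so the size of its effect cannot be read from the data shown. Compound 2 and compound 1 each carry a phenyl on the core, though with other groups elsewhere, and both sit at a limit as well. Because (the limit of > 20000 nM in this assay, at which 3 of the 3 values shown sit), the expectation for compound 4 in this assay is a step that the limit leaves unreadable from compound 3 to compound 4, which means no change expected beyond the scatter. Compound 4 is therefore estimated at 30000 nM, within 8000 nM to 100000 nM, and most likely this assay will again report only a limit.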

Compound 4, half-maximal inhibitory concentration: > 20000 nM
Compound 4 was reported as a limit; the forecaster's own chance of this, stated with the estimate: 85%; the middle value lies beyond the limit too.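

In this assay compound 4 gives only a limit, > 20000 nM. Compound 2 and compound 3 also stop at limits, so neither step to compound 4, phenyl in place of thiophen-3-yl or methylamino in place of methoxy, can be read. What the compounds shown leave open is which groups on the shared core would give a measurable value in this assay, given what they show so far: the limit of > 20000 nM in this assay, at which 4 of the 4 values shown sit.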